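A few compounds are considered here, and "the series" means these few. Any claim that something is new, unique, unknown or untested is made for them only; others in the source may bear on it.

Measured in a functional assay on COLO 205 cells (Homo sapiens) for inhibition, read by sulforhodamine B assay; on this read-out higher numbers stand for weaker inhibition of growth and lower numbers for stronger inhibition of growth:
- compound 1 `c1ccc(-c2ccc(-c3ccc(-c4nc5ccccc5[nH]4)cc3)cc2)cc1`: 100000 nM
- compound 2 `FC(F)(F)c1ccc(-c2ccc(-c3ccc(-c4nc5ccccc5[nH]4)cc3)cc2)cc1`: 33900 nM
- compound 3 `Oc1ccc(-c2ccc(-c3ccc(-c4nc5ccccc5[nH]4)cc3)cc2)cc1`: 100000 nM

Compound 3 stands level with compound 1, the two sharing the highest number of the three, and the step between them is no change at the digits printed from compound 1 to compound 3 (within the scatter). Compound 2 is the only one apart from them, with a 2.9-fold higher number from compound 2 to compound 3 (0.47 log units; beyond the scatter).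

The next compound, compound 4 `CN(C)c1ccc(-c2ccc(-c3ccc(-c4nc5ccccc5[nH]4)cc3)cc2)cc1`, carries dimethylamino in place of hydroxy on an aromatic carbon, para to a large group: dimethylamino in place of hydroxy on an aromatic carbon.

Among the compounds with values here, no measured compound carries dimethylamino, so the data offer no direct precedent, and only the three steps among the measured compounds bear on this change. Replacing hydrogen with hydroxy gave no change at the digits printed from compound 1 to compound 3 (within the scatter), while replacing hydrogen with trifluoromethyl gave a 2.9-fold lower number from compound 1 to compound 2 (0.47 log units; beyond the scatter), a modest step. Replacing hydroxy with trifluoromethyl is the reverse of the step already given for compound 2, so it adds no separate evidence.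

With only modest movement seen so far in this assay, a small step toward a lower number is expected, and no change beyond the scatter remains possible. The expected step is a 2.0-fold lower number from compound 3 to compound 4 (0.30 log units; within the scatter). Compound 4 is estimated at 50000 nM, with an expected range from 15000 nM to 100000 nM.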

Compound 4, concentration for 50% growth inhibition: 100000 nM
Estimate against measurement, compound 4: 2.0-fold (0.30 log units) below, and the stated range covers the measured number.
By their numbers in this assay, from the lowest: compound 2; then compounds 1, 3 and 4 (each within the scatter of the next).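

In this assay, dimethylamino on an aromatic carbon para to a large group joins hydroxy and hydrogen at this place: the exchange for hydroxy gives no change at the digits printed from compound 3 to compound 4 (within the scatter), and the exchange for hydrogen gives no change at the digits printed from compound 1 to compound 4 (within the scatter). Against trifluoromethyl the same place reads a 2.9-fold higher number from compound 2 to compound 4 (0.47 log units; beyond the scatter), so among these four compounds, compound 2 alone stands apart, now from three compounds instead of two. The earlier compounds shown here could not show that going from hydroxy, with 1 heavy atom and 1 hydrogen-bond donor, to dimethylamino, with 3 heavy atoms and 0 hydrogen-bond donors, would leave the printed number unmoved at this place.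

Nothing measured here accounts for why trifluoromethyl alone departs from the other three groups. From the compounds shown here alone, whether a nitrile, a carboxylic acid or a longer chain at this place would follow trifluoromethyl to a lower number or stay with hydrogen, hydroxy and dimethylamino remains open.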